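The source may hold more compounds than are shown below. What is called first, only, known or untested is meant among the compounds shown, and "the series" means these compounds.

Measured compounds:
compound 1, `O=C(Nc1cccc(CNc2ncnc3ccccc23)c1)Nc1ccccc1F`, 33400 nM
compound 2, `O=C(Nc1ccc(F)cc1)Nc1cccc(CNc2ncnc3ccccc23)c1`, 44300 nM
compound 3, `COc1cc2ncnc(NCc3cccc(NC(=O)Nc4ccccc4F)c3)c2cc1OC`, 10300 nM

All three were tested in a functional assay on MGC-803 cells (Homo sapiens) for antiproliferative activity, read by MTT assay; on this read-out lower numbers stand for stronger inhibition and higher numbers for weaker inhibition. Compound 1 and compound 2 share a core and differ only by 4-fluorophenyl in place of 2-fluorophenyl on an amide-type nitrogen; that change gave a 1.3-fold higher number from compound 1 to compound 2 (0.12 log units; within the scatter). Compound 3 carries a different core, and the difference between the two cores is not broken down here. In this assay compound 3 gives the lowest of the three numbers, and its step to compound 1 and to compound 2 lies beyond the scatter in each case.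

Compound 4, `COc1cc2ncnc(NCc3cccc(NC(=O)Nc4ccc(F)cc4)c3)c2cc1OC`, has not yet been measured. For the measured compounds named here, it differs from compound 3 by 4-fluorophenyl in place of 2-fluorophenyl on an amide-type nitrogen, which is the same change, at the same place, as the one made from compound 1 to compound 2. Since that change gave a 1.3-fold higher number from compound 1 to compound 2 (0.12 log units; within the scatter), a step of similar size is expected from compound 3 to compound 4, namely a 1.3-fold higher number from compound 3 to compound 4 (0.10 log units; within the scatter). On that basis compound 4 is estimated at 13000 nM, with a likely range from 6000 nM to 30000 nM.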

Compound 4, half-maximal inhibitory concentration: 42100 nM
The estimate for compound 4 lay 3.2-fold (0.51 log units) below the measured number; the measured number lies above the stated range.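

In this assay the change from 2-fluorophenyl to 4-fluorophenyl on the amide-type nitrogen gave a 4.1-fold higher number from compound 3 to compound 4 (0.61 log units; beyond the scatter) on the core of compound 3. The same change stayed within the scatter on the core of compound 1, so the size of its step did not carry from one core to the other: the same change on two cores in this assay, a 1.3-fold higher number (0.12 log units; within the scatter) from compound 1 to compound 2 and a 4.1-fold higher number (0.61 log units; beyond the scatter) from compound 3 to compound 4, 3.1-fold (0.49 log units) apart, beyond the scatter of two such steps

This shows that, for these two cores, a step measured on one was a poor guide to the step on the other, but two pairs give no general rule for the series and do not show which feature of the cores lies behind the gap.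

From the compounds shown here alone, all four compounds carry a fluorophenyl group on this nitrogen, so it stays open whether a chlorophenyl or a methylphenyl group there would also give steps of different size on the two cores. Going by these compounds, it also stays open how the change from 2-fluorophenyl to 4-fluorophenyl would read on any third core.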